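Hydroxy on the fused ring: a second core

The source may report more compounds than this note shows. Statements on the series, on what has been measured and on what is new or still open speak of the compounds shown alone.

Working notes on a small set of quinone-type compounds tested in a functional assay on DU-145 cells (Homo sapiens) for inhibition, read by MTT assay, with a stated time of 72 h; on this read-out higher numbers stand for weaker inhibition and lower numbers for stronger inhibition.

Compound 1 `Cc1ccccc1N1CCN(C2=CC(=O)c3ccccc3C2=O)CC1` gives 5700 nM in this assay. Compound 2 `Cc1ccccc1N1CCN(C2=CC(=O)c3cccc(O)c3C2=O)CC1` carries the change hydroxy in place of hydrogen on an aromatic carbon and gives 2300 nM in this assay. Among the measured compounds shown here, the step of a 2.5-fold lower number from compound 1 to compound 2 (0.39 log units; beyond the scatter) is the only measured instance of this change so far.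

Compound 3 `O=C1C=C(N2CCC(c3ccccc3)CC2)C(=O)c2ccccc21` rests on a different core; the difference between the two cores is not broken down here. In this assay, for the measured compounds named here, compound 3 gives 6000 nM, a number that sits within the scatter of the one given by compound 1, so no order between compound 1 and compound 3 is claimed.

Compound 4 `O=C1C=C(N2CCC(c3ccccc3)CC2)C(=O)c2c(O)cccc21` is not yet measured. It differs from compound 3 by hydroxy in place of hydrogen on an aromatic carbon, the same change that separates compound 2 from compound 1: the leaving hydrogen, the entering hydroxy and the place on the fused ring all match word for word.

On a single precedent, the step from compound 3 to compound 4 is expected to be a 2.3-fold lower number from compound 3 to compound 4 (0.36 log units; beyond the scatter), close to the modest step seen as a 2.5-fold lower number from compound 1 to compound 2 (0.39 log units; beyond the scatter), since the two cores give nearly the same starting numbers. Compound 4 is therefore expected to give about 2600 nM in this assay, with a range from 1200 nM to 5500 nM that allows the change to fall within the scatter on the new core.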

Compound 4, half-maximal inhibitory concentration: 3000 nM
The estimate for compound 4 lay 1.2-fold (0.06 log units) below the measured number, and the stated range covers the measured number.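

In this assay, hydroxy in place of hydrogen on an aromatic carbon gives a 2.0-fold lower number from compound 3 to compound 4 (0.30 log units; within the scatter), so on the core of compound 3 this step alone does not clear the scatter. Set beside the earlier step, it cannot be told apart in size, which fits the change carrying over from the core of compound 1 to the core of compound 3: the same change on two cores in this assay, a 2.5-fold lower number (0.39 log units; beyond the scatter) from compound 1 to compound 2 and a 2.0-fold lower number (0.30 log units; within the scatter) from compound 3 to compound 4, 1.2-fold (0.09 log units) apart, within the scatter of two such steps. Among the compounds shown here, this rests on only two pairs, with the hydroxy at one place on the fused ring and only one of the two steps beyond the scatter, so it shows neither that the change holds on any further core nor what lies behind the steps.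

The compounds shown leave open whether other groups at this place, such as a methoxy group, an amine or a carboxylic acid, would give steps like those of the hydroxy. Going by these compounds, it also remains open whether a hydroxy elsewhere on the fused ring, or on the phenyl ring of either core, would give a step of like size.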